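The source may report more compounds than this note shows. Statements on the series, on what has been measured and on what is new or still open speak of the compounds shown alone.

In a functional assay on cells (Neutrophil, Homo sapiens) for inhibition, with a stated time of 10 min (on this read-out higher numbers stand for weaker inhibition and lower numbers for stronger inhibition), three compounds have been measured so far:

Compound 1 `CCOC(=O)c1cnn(CC(O)CC)c1NC(=O)Nc1ccccc1F` gives 120 nM.
Compound 2 `CCOC(=O)c1cnn(CC(C)O)c1NC(=O)Nc1ccccc1F` gives 100 nM.
Compound 3 `CCCC(O)Cn1ncc(C(=O)OCC)c1NC(=O)NCc1ccccc1` gives 0.43 nM.

Compound 1 and compound 2 share a core and differ only by hydrogen in place of methyl on a saturated chain carbon, two bonds along the chain from an oxygen on a saturated carbon, a change that gave a 1.2-fold lower number from compound 1 to compound 2 (0.08 log units; within the scatter). Compound 3 is built on a different core; the difference between the two cores is not broken down here, and its number lies far below that of compound 2. Compound 4 `CCOC(=O)c1cnn(CC(O)CC)c1NC(=O)NCc1ccccc1`, not yet measured, is reached from compound 3 by hydrogen in place of methyl on a saturated chain carbon, three bonds along the chain from an oxygen on a saturated carbon. This is the same kind of change as that from compound 1 to compound 2, but its place differs: there the hydrogen enters two bonds along the chain from an oxygen on a saturated carbon, here three bonds along the chain. Because a 1.2-fold lower number from compound 1 to compound 2 (0.08 log units; within the scatter) the expectation in this assay is a similarly small step, namely a 1.2-fold higher number from compound 3 to compound 4 (0.07 log units; within the scatter). Compound 4 is therefore estimated at 0.5 nM, with a likely range from 0.2 nM to 1.3 nM.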

Compound 4, half-maximal inhibitory concentration: > 10 nM
Compound 4 ended at the assay's limit; the forecaster's own chance of this, stated with the estimate: 2%; middle value at least 20-fold (1.30 log units) away from the limit.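

In this assay compound 4 gives > 10 nM, which is a limit of the assay and not a number. Shortening propyl to ethyl on this core produces an at least 23-fold higher number from compound 3 to compound 4 (1.36 log units; beyond the scatter), so the replacement of methyl by hydrogen does not carry over unchanged from one core to the other: the same change on two cores in this assay, a 1.2-fold lower number (0.08 log units; within the scatter) from compound 1 to compound 2 and an at least 23-fold higher number (1.36 log units; beyond the scatter) from compound 3 to compound 4, at least 27-fold (1.44 log units) apart, beyond the scatter of two such steps. The two steps also differ in place, two bonds along the chain from the oxygen in one and three bonds in the other, so they do not show whether core or place accounts for the gap, and the step between compound 1 and compound 4 cannot be read.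

The compounds shown leave open how a longer chain, such as butyl, would behave on either core. They also leave open whether an amine in place of the hydroxyl group would keep the low number of compound 3.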